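The source may hold more compounds than are shown below. What is called first, only, known or untested is meant among the compounds shown, and "the series" means these compounds.

Compound 1 `Cc1ccccc1Nc1nc(NCc2ccccc2)ncc1Cl` gives only a limit in a functional assay on MCF7 cells (Homo sapiens) for inhibition, read by CCK-8 assay, with a stated time of 48 h (on this read-out higher numbers stand for weaker inhibition of growth and lower numbers for stronger inhibition of growth), > 100000 nM. Compound 2 `Cc1ccccc1Nc1nc(Nc2ccccn2)ncc1Cl` gives 31400 nM. Compound 3 `CN1CCN(c2ccc(Nc3ncc(Cl)c(NCc4ccccc4)n3)nc2)CC1` gives 17300 nM.

Compound 3 and compound 2 sit within the scatter of each other, so neither can be ranked against the other; the value of compound 1 is a limit. Compound 4 `COc1ccc(Nc2nc(Nc3ccc(N4CCN(C)CC4)cn3)ncc2Cl)cc1` differs from compound 3 in one place: 4-methoxyphenyl in place of benzyl on a nitrogen on an aromatic ring. For the measured compounds named here, one measured step bears on this change, an at least 3.1-fold lower number from compound 1 to compound 2 (0.50 log units; beyond the scatter), where benzyl on a nitrogen on an aromatic ring was likewise replaced by an aromatic ring; that step went to a lower number, though it starts from a limit (the limit of > 100000 nM in this assay, at which 1 of the 3 values shown sits). A lowering step of comparable size is therefore expected for compound 4, a 2.9-fold lower number from compound 3 to compound 4 (0.46 log units; beyond the scatter). Compound 4 is estimated at 6000 nM, within 1500 nM to 25000 nM.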

Compound 4, concentration for 50% growth inhibition: 8450 nM
For compound 4 the middle estimate is 1.4-fold (0.15 log units) below the measured one; the range from low to high includes it.
By their numbers in this assay, from the lowest: compound 4; then compounds 3 and 2 (each within the scatter of the next). At a limit, above all of these: compound 1.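

On this nitrogen, 4-methoxyphenyl in place of benzyl gives a 2.0-fold lower number from compound 3 to compound 4 (0.31 log units; beyond the scatter) in this assay, so a lowering at this position now has a size read between two numbers. The earlier replacement of benzyl by an aromatic ring started from compound 1, whose value is a limit: the limit of > 100000 nM in this assay, at which 1 of the 4 values shown sits. The lowering also now appears on a second core, that of compound 3.

As far as these compounds go, it remains open whether an amine or a carboxylic acid in place of the methoxy group on the phenyl ring would take the number lower still. From the compounds shown here alone, a longer chain between this nitrogen and the phenyl ring is also open.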